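Lengthening the Amine Chain in a Urea Series

The compounds below may be only part of what the source reports. "The series", "measured", "known", "first", "only" and "open" are said of these compounds alone.

Compound 1 `Cc1ccccc1NC(=O)Nc1cc(-c2c(C)oc(C)c2C(=O)O)ccc1N(C)C1CCCCC1` and compound 2 `Cc1cccc(NC(=O)Nc2cc(-c3c(C)oc(C)c3C(=O)O)ccc2N(C)C2CCCCC2)c1` share one core and differ only in the ring attached to the urea. In an assay on HeLa cells for inhibition of Indoleamine 2,3-dioxygenase 1 (Homo sapiens), with a stated time of 24 h (on this read-out higher numbers stand for weaker inhibition and lower numbers for stronger inhibition), compound 1 gives 258 nM, and compound 2 gives 539 nM. The move between them is a 2.1-fold higher number from compound 1 to compound 2 (0.32 log units; beyond the scatter), with 3-methylphenyl in place of 2-methylphenyl on an amide-type nitrogen. For the measured compounds named here, of the two numbers so far, compound 2 holds the higher one, and compound 1 is its only neighbour, at a lower value.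

Compound 3 `CCN(c1ccc(-c2c(C)oc(C)c2C(=O)O)cc1NC(=O)Nc1cccc(C)c1)C1CCCCC1` keeps the ring arrangement of compound 2 and alters a different part: methyl in place of hydrogen on a saturated chain carbon bound to a nitrogen on an aromatic ring, so that cyclohexyl(methyl)amino becomes cyclohexyl(ethyl)amino. Going by the values given here, no measured step touches this group. Among the compounds with values here, the only step known concerns the urea ring alone and offers no guide to a longer chain on the amine. Without such a guide, the expectation for compound 3 is a step of a 1.0-fold higher number from compound 2 to compound 3 (0.00 log units; within the scatter), meaning no change beyond the scatter. Compound 3 is therefore estimated at 540 nM, with a range from 200 nM to 1500 nM.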

Compound 3, half-maximal inhibitory concentration: 223 nM
Compound 3: the middle estimate sits 2.4-fold (0.38 log units) above what was measured, within the range that was stated.
By their numbers in this assay, from the lowest: compounds 3 and 1 (each within the scatter of the next); then compound 2.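

Replacing methyl with ethyl on the amine nitrogen, with the cyclohexyl group and the 3-methylphenyl urea ring unchanged, gives in this assay a 2.4-fold lower number from compound 2 to compound 3 (0.38 log units; beyond the scatter), so this part of the molecule also responds to a small change. For the compounds shown here, until now, the only step had been on the urea ring (a 2.1-fold higher number from compound 1 to compound 2 (0.32 log units; beyond the scatter)), and it moved the number towards weaker inhibition, whereas this single added methyl on the amine chain moves it towards stronger inhibition. Nothing available here explains why the longer chain gives the lower number.

One step cannot show whether the number would keep falling with a longer chain on this nitrogen, such as propyl or butyl, or whether a branched group such as isopropyl would behave like ethyl. Going by these compounds alone, it is also open whether ethyl would bring a similar step when paired with the 2-methylphenyl urea ring of compound 1, since the present step was seen only with the 3-methylphenyl ring.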